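The source may hold more compounds than are shown below. What is called first, only, known or untested is meant among the compounds shown, and "the series" means these compounds.

Among the compounds with values here, in an ADME assay on MT4 cells (Homo sapiens) for cytotoxicity, read by spectrophotometry, with a stated time of 5 days (on this read-out higher numbers stand for lower toxicity in this test and lower numbers for higher toxicity in this test), compound 1 (`COc1ccc(N2CCN(CN3C(=O)/C(=N\NC(=S)NO)c4cc(F)ccc43)CC2)cc1`) gives 260000 nM and compound 2 (`COc1ccc(N2CCN(CN3C(=O)/C(=N\NC(=S)NO)c4cc(Cl)ccc43)CC2)cc1`) gives 279000 nM, so compound 1 cannot be told apart from the only other compound measured. Within the data shown here, that one step, a 1.1-fold higher number from compound 1 to compound 2 (0.03 log units; within the scatter), is chloro in place of fluoro, a different change from the one in compound 3 (`O=C1/C(=N\NC(=S)NO)c2cc(F)ccc2N1CN1CCN(c2ccccc2)CC1`), which has hydrogen in place of methoxy on an aromatic carbon. Among the measured compounds shown here, no measured step covers this change, so no shift beyond the scatter is expected, and the direction stays open. The expected step is a 1.0-fold lower number from compound 1 to compound 3 (0.02 log units; within the scatter). For compound 3 the estimated value is 250000 nM, within a range of 120000 nM to 500000 nM.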

Compound 3, half-maximal cytotoxic concentration: 251000 nM
Beside the measured number, compound 3's estimate is 1.0-fold (0.00 log units) below it, within the range that was stated.
By their numbers in this assay, from the lowest: compounds 3, 1 and 2 (each within the scatter of the next).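

Going from 4-methoxyphenyl to phenyl gives a 1.0-fold lower number from compound 1 to compound 3 (0.02 log units; within the scatter) in this assay, so on this aromatic carbon hydrogen in place of methoxy produces no shift beyond the scatter. The earlier compounds shown here varied only chloro in place of fluoro and left this place unchanged. No measured evidence bears on this result.

The compounds shown leave open whether an amine, a carboxylic acid or a longer chain on this aromatic carbon would also stay within the scatter. They also leave open whether hydrogen in place of methoxy reads the same in the chloro series.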